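The compounds below may be only part of what the source reports. "The series", "measured", "known", "first", "only" and "open" are said of these compounds alone.

Working notes on the series.

Compound 1 `CSc1nncc2c(C)nc(C)n12` is the reference. In a functional assay for inhibition, with Homo sapiens as the target (a higher number here means a weaker inhibitor, a lower number a stronger inhibitor), compound 1 reaches only the limit of > 48000 nM. Compound 2 `CCCc1nc(C)c2cnnc(SC)n12` carries the change (ethyl in place of hydrogen on a saturated chain carbon bound to an aromatic carbon); the listed difference is the same as the one computed for compound 4 below, the place line reading word for word alike. In this assay compound 2 also reaches only the limit of > 48000 nM. The step that the two limits leave unreadable from compound 1 to compound 2 is therefore not readable in either direction.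

Compound 3 `Cc1nc(C)n2c(O)nncc12` differs from compound 1 by hydroxy in place of methylsulfanyl on an aromatic carbon; that is the difference between the two cores. In this assay compound 3 again sits at the limit of > 48000 nM. The step that the two limits leave unreadable from compound 1 to compound 3 is likewise not readable.

For the measured compounds named here, the common ground across the three measured compounds is the limit of > 48000 nM in this assay, at which 3 of the 3 values shown sit, which leaves no measured step of any size to read from.

Compound 4 `CCCc1nc(C)n2c(O)nncc12` carries the change ethyl in place of hydrogen on a saturated chain carbon bound to an aromatic carbon on the core of compound 3. Because the step that the two limits leave unreadable from compound 1 to compound 2 on the core of compound 1 gave no readable size, and because compound 3 stands at > 48000 nM, the same change on the core of compound 3 is expected to leave compound 4 at or near the limit, with the step that the limit leaves unreadable from compound 3 to compound 4 expected to be small or unreadable. The estimate for compound 4 in this assay is 70000 nM, expected to lie between 30000 nM and 200000 nM, most likely reported again only as a limit.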

Compound 4, half-maximal inhibitory concentration: > 48000 nM
Compound 4 gave a limit, no number; the forecaster's own chance of this, stated with the estimate: 85%; the middle value does not contradict the limit.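

In this assay compound 3 and compound 4 stand only at a limit, not at a number, so no new step can be read between them. The four compounds share this position: the limit of > 48000 nM in this assay, at which 4 of the 4 values shown sit. The compounds shown leave open whether any change on these cores gives a measurable value in this assay and how large the ethyl change would be on a readable value.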